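Trifluoromethyl for trifluoromethoxy in the series

The source may hold more compounds than are shown below. What is called first, only, known or untested is meant among the compounds shown, and "the series" means these compounds.

Values in an in vitro ADME assay on microsomes from liver (Homo sapiens) for metabolic stability, in the presence of a further agent that is not named here; on this read-out higher numbers stand for fast clearance and lower numbers for slow clearance
Compound 1 `COc1ccc(OC(F)(F)F)cc1Cn1c(C(=O)NCC(C)(C)CO)cc2cc(C#N)ccc21` gives 31 mL.min-1.g-1
Compound 2 `COc1ccc(OC(F)(F)F)cc1Cn1c(C(=O)NCC2(CO)CC2)cc2cc(C#N)ccc21` gives 18 mL.min-1.g-1

Compound 2 (18 mL.min-1.g-1) and compound 1 (31 mL.min-1.g-1) lie within the scatter of each other. Compound 3 `COc1ccc(C(F)(F)F)cc1Cn1c(C(=O)NCC2(CO)CC2)cc2cc(C#N)ccc21` differs from compound 2 by one change (trifluoromethyl in place of trifluoromethoxy on an aromatic carbon), trifluoromethyl in place of trifluoromethoxy on an aromatic carbon. Within the data shown here, the only measured step (a 1.7-fold lower number from compound 1 to compound 2 (0.24 log units; within the scatter)) lies elsewhere in the molecule and stays within the scatter, so it bears only weakly on this change. No step beyond the scatter is expected in this assay for this exchange. The estimated step is small (a 1.1-fold lower number from compound 2 to compound 3 (0.02 log units; within the scatter)). Compound 3 is estimated at 17 mL.min-1.g-1 (expected range 8 mL.min-1.g-1 to 35 mL.min-1.g-1).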

Compound 3, intrinsic clearance in microsomes: 7 mL.min-1.g-1
Estimate against measurement, compound 3: 2.4-fold (0.39 log units) above; measured number outside the range, below it.
By their numbers in this assay, from the lowest: compound 3; then compounds 2 and 1 (each within the scatter of the next).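

In this assay, among these compounds, the aromatic carbon para to a methoxy group proves sensitive: trifluoromethyl in place of trifluoromethoxy gives a 2.6-fold lower number from compound 2 to compound 3 (0.41 log units; beyond the scatter) and so moves the number beyond the scatter, which the one earlier step, on the amide side chain, did not do. No measurement here accounts for this step.

Open, going by these compounds, is whether the exchange gives a similar step with the 1-(hydroxymethyl)-1-methylethyl side chain of compound 1. Also open, on these data alone, is how a chlorine, a methyl or a nitrile would read at this aromatic carbon.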